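The compounds below may be only part of what the source reports. "The series", "measured", "known", "first", "only" and "open" are said of these compounds alone.

compound 1 `Cc1[nH]c2ccc([N+](=O)[O-])cc2c1C1(c2c(C)[nH]c3ccc([N+](=O)[O-])cc23)C(=O)Nc2ccccc21` gives 940 nM
compound 2 `O=C1Nc2ccccc2C1(c1c(-c2ccccc2)[nH]c2ccccc12)c1c(-c2ccccc2)[nH]c2ccccc12` gives 9600 nM

In a functional assay on SK-N-SH cells (Homo sapiens) for cytotoxicity, read by MTT assay, with a stated time of 48 h (on this read-out lower numbers stand for stronger inhibition and higher numbers for weaker inhibition), compound 1 (940 nM) stands lowest of the two, and compound 2 (9600 nM) lies beyond the scatter above it. Compound 3 `Cc1[nH]c2ccc([N+](=O)[O-])cc2c1C1(c2c(C)[nH]c3ccc([N+](=O)[O-])cc23)C(=O)Nc2ccc(Cl)cc21` keeps the core of compound 1 with one change (chloro in place of hydrogen on an aromatic carbon): chloro in place of hydrogen on an aromatic carbon. Among the measured compounds shown here, no measured pair shows this change, so the expectation is a loose one. In this assay a small move toward lower numbers is expected, perhaps none beyond the scatter (a 1.3-fold lower number from compound 1 to compound 3 (0.13 log units; within the scatter)). The estimated value for compound 3 is 700 nM (expected range 250 nM to 2000 nM).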

Compound 3, half-maximal inhibitory concentration: 1230 nM
Compound 3: middle estimate off by 1.8-fold (0.24 log units), on the low side, within the range that was stated.
By their numbers in this assay, from the lowest: compounds 1 and 3 (each within the scatter of the next); then compound 2.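

In this assay, placing chloro on this aromatic carbon, meta to a fused ring and para to a fused ring, gives a 1.3-fold higher number from compound 1 to compound 3 (0.12 log units; within the scatter) and so leaves the number within the scatter. This position therefore accepts a single chlorine atom on the core of compound 1 with no measurable change in this cell assay. Nothing available explains this outcome. As far as these compounds go, whether an amine, a methoxy group or a carboxylic acid at this same carbon would also leave the number unchanged remains open. So does the effect of chloro on other aromatic carbons.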